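The source may hold more compounds than are shown below. What is called first, only, known or untested is meant among the compounds shown, and "the series" means these compounds.

In a functional assay for antagonist activity at transient receptor potential cation channel subfamily V member 1 (Homo sapiens), read by FLIPR and calcium flux (on this read-out lower numbers stand for stronger inhibition and higher numbers for weaker inhibition), three compounds have been measured. Compound 1 `O=C1CSc2ccc(NC(=O)C3CCN(c4cc(F)c(F)c(F)c4)CC3)cc2N1` gives 1960 nM. Compound 2 `O=C1COc2ccc(NC(=O)C3CCN(c4cccc(Cl)c4)CC3)cc2N1` gives 190 nM, and compound 3 `O=C(Nc1cccc2[nH]ccc12)C1CCN(c2cccc(C(F)(F)F)c2)CC1` gives 230 nM. Compound 2 and compound 3 sit within the usual scatter of one another, so neither can be called the stronger; compound 1 sits beyond that scatter with a weaker reading. Compound 4 `CC(C)c1ccccc1N1CCC(C(=O)Nc2ccc3c(c2)NC(=O)CO3)CC1` differs from compound 2 in one place: 2-isopropylphenyl in place of 3-chlorophenyl on an amine nitrogen in a ring. Among the measured compounds shown here, no measured pair shows this exact change, so only an expectation can be stated. In this assay a modest step toward weaker inhibition is expected, possibly still within the scatter. The step expected from compound 2 to compound 4 is a 2.1-fold higher number from compound 2 to compound 4 (0.32 log units; beyond the scatter). Compound 4 is thus estimated at 400 nM, with a range from 120 nM to 1300 nM.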

Compound 4, half-maximal inhibitory concentration: 180 nM
Estimate against measurement, compound 4: 2.2-fold (0.35 log units) above; the measured number falls inside the stated range.
By their numbers in this assay, from the lowest: compounds 4, 2 and 3 (each within the scatter of the next); then compound 1.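

In this assay putting 2-isopropylphenyl in place of 3-chlorophenyl on the amine nitrogen in the ring gives a 1.1-fold lower number from compound 2 to compound 4 (0.02 log units; within the scatter) and stays within the scatter. This place on the shared core therefore takes a larger, chlorine-free group made only of carbon with no measurable change in inhibition. The compounds shown leave open how a carboxylic acid or an amine on that phenyl ring would read, and whether 2-isopropylphenyl behaves the same way on the core of compound 3. No available evidence explains why these two groups read alike.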